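A Larger Acetylated Ring on the Chain of Compound 2

The compounds below may be only part of what the source reports. "The series", "measured", "known", "first", "only" and "open" are said of these compounds alone.

Compound 1 `COc1cccc(-c2cc(NC(=O)CCCCN3CCCCC3)[nH]n2)c1` and compound 2 `COc1ccc(-c2n[nH]c(NC(=O)CCCCN3CCCCC3)c2C)cc1` have both been tested in an ADME assay for permeability, using PAMPA, with a stated time of 4 h, tested at 10 uM; a lower number here means that the compound crosses the layer more slowly, a higher number that the compound crosses the layer faster. Compound 1 gives > 10 10^-6 cm/s as a limit of the assay, not a number. Compound 2 gives > 10 10^-6 cm/s, also a limit, and it stands at the limit of > 10 10^-6 cm/s in this assay, at which 2 of the 2 values shown sit, with no exact value. Compound 3 `COc1ccc(-c2n[nH]c(NC(=O)CCCCN3CCCN(C(C)=O)CC3)c2C)cc1` has 4-acetyl-1,4-diazepan-1-yl in place of piperidin-1-yl on a saturated chain carbon, four bonds along the chain from a carbonyl carbon. No measured step among these compounds shows the effect of such a change, so the expectation rests on the structural difference alone. A modest decrease is expected in this assay, estimated as an at least 2.0-fold lower number from compound 2 to compound 3 (0.30 log units; that floor lies within the scatter), and it may not clear the usual scatter. For compound 3 the expected value is 5 10^-6 cm/s, with an estimated range from 1.5 10^-6 cm/s to 14 10^-6 cm/s in apparent permeability.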

Compound 3, apparent permeability: 2 10^-6 cm/s
Compound 3: middle estimate off by 2.5-fold (0.40 log units), on the high side; the range from low to high includes it.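

In this assay, the saturated chain carbon four bonds along the chain from a carbonyl carbon now proves sensitive to the group it carries: 4-acetyl-1,4-diazepan-1-yl in place of piperidin-1-yl gives an at least 5.0-fold lower number from compound 2 to compound 3 (0.69 log units; beyond the scatter). Among the compounds shown here, compound 3, at 2 10^-6 cm/s, has the only exact number among the three compounds, so this change gives the first readable step at this position. Compound 2 gives a limit of the assay and not a number, so the step marks only a floor and its full size stays unknown: the limit of > 10 10^-6 cm/s in this assay, at which 2 of the 3 values shown sit.

For the compounds shown here, the single step changes the ring and adds the acetyl together, so it cannot show which of the two accounts for the drop. A 1,4-diazepan-1-yl ring without the acetyl or a 4-acetylpiperazin-1-yl ring at this place would separate the two, and neither is among the compounds shown.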